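Series notes: step from compound 3 to compound 4

This account rests on a few compounds, and the source may have more. Where it says the series, first, only, none or still open, it means among the compounds named here.

Measured compounds:
compound 1 `COc1ccc(Cn2c(=O)nc(NCCNC(=N)N)n(Cc3ccc(C)cc3)c2=O)cc1` gives 0.0045 nM in a functional assay on the whole organism (strain C57Bl/6) for inhibition, with Mus musculus as the target, with a stated time of 180 min, at 48 degrees C; on this read-out lower numbers stand for an effect already at smaller amounts and higher numbers for an effect only at larger amounts of compound
compound 2 `COc1ccc(Cn2c(=O)nc(NCCNC(=N)N)n(Cc3ccccc3)c2=O)cc1` gives 0.063 nM
compound 3 `COc1ccc(Cn2c(NCCNC(=N)N)nc(=O)n(Cc3ccc(I)cc3)c2=O)cc1` gives 0.051 nM

Compound 3 stands second highest of the three numbers. Its nearest neighbour is compound 2, whose value lies within the scatter of that of compound 3, so no order between the two is claimed. Compound 1 lies furthest away, with a number well below that of compound 3, beyond the scatter.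

Compound 4 `COc1ccc(Cn2c(NCCNC(=N)N)nc(=O)n(Cc3ccc(OC)cc3)c2=O)cc1` is not yet measured. It differs from compound 3 as follows: methoxy in place of iodo on an aromatic carbon

Among the compounds with values here, one measured step bears on this group: a 14-fold higher number from compound 1 to compound 2 (1.15 log units; beyond the scatter). That step shows that the group on this aromatic carbon, para to a large group, can move the number strongly. Compound 3, carrying iodo at the same place, sits close to compound 2 with hydrogen, so not every group there repeats the effect of methyl. Within the data shown here, no step between iodo and methoxy is measured, and the direction for compound 4 is open. Given the spread between compound 1 and compound 3, the estimated step for compound 4 is a 1.7-fold lower number from compound 3 to compound 4 (0.23 log units; within the scatter), a modest change toward a lower number, with a wide range. Compound 4 is expected to give 0.03 nM, between 0.005 nM and 0.15 nM.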

Compound 4, half-maximal effective concentration: 0.000053 nM
Compound 4: the middle estimate sits 570-fold (2.75 log units) above what was measured; the measured number lies below the stated range.
By their numbers in this assay, from the lowest: compound 4; then compound 1; then compounds 3 and 2 (each within the scatter of the next).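

In this assay the group on this aromatic carbon, para to a large group, proves able to move the number far more than the methyl-for-hydrogen exchange had shown, for methoxy in place of iodo gives the largest kind of change seen here (a 960-fold lower number from compound 3 to compound 4 (2.98 log units; beyond the scatter)) and methoxy in place of hydrogen gives a change of the same kind (a 1200-fold lower number from compound 2 to compound 4 (3.08 log units; beyond the scatter)). Methyl no longer marks the low end at this place, since methoxy goes well past it (an 85-fold lower number from compound 1 to compound 4 (1.93 log units; beyond the scatter)). The order at this place now reads methoxy, then methyl, then iodo and hydrogen with no order between the last two, so among these four compounds a group here does not lower the number merely by being present, as compound 3 with iodo shows.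

From the compounds shown here alone, whether an ethoxy group, a hydroxy group or an amine at this same place would follow methoxy, or whether the steep drop belongs to methoxy alone, remains open. Nothing at hand accounts for the size of these steps, and the reason for them stays unexplained.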